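Swapping a methyl for hydrogen on a weak benzothiazole analogue

The compounds below may be only part of what the source reports. "The series", "measured", "known", "first", "only" and "open" are said of these compounds alone.

Measured so far:
Compound 1, `Oc1ccc(-c2nc3cc(F)ccc3s2)cc1O`: 1640 nM
Compound 2, `COc1cc(-c2nc3cc(F)ccc3s2)ccc1O`: 1040 nM
Compound 3, `COc1cc(-c2nc3cc(F)ccc3s2)cc(OC)c1OC`: 21100 nM

All three share a core and were tested in a functional assay on HCC 2998 cells (Homo sapiens) for antiproliferative activity; a lower number here means a stronger inhibitor of growth, a higher number a weaker inhibitor of growth. Compound 2 and compound 1 differ only by hydrogen in place of methyl on an oxygen on an aromatic ring, and this gave a 1.6-fold higher number from compound 2 to compound 1 (0.20 log units; within the scatter), so the two cannot be told apart. Compound 3 stands highest of the three; the difference between its core and that of compound 2 is not broken down here.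

Compound 4, `COc1cc(-c2nc3cc(F)ccc3s2)cc(O)c1OC`, is not yet measured. Within the data shown here, it arises from compound 3 by hydrogen in place of methyl on an oxygen on an aromatic ring, the same change as the one from compound 2 to compound 1. Because a 1.6-fold higher number from compound 2 to compound 1 (0.20 log units; within the scatter) lay within the scatter, a similarly small step is expected here, though the weaker starting point of compound 3, 21100 nM, leaves the direction open. Compound 4 is therefore expected to give about 12000 nM, between 4000 nM and 40000 nM. That expectation corresponds to an estimated step of a 1.8-fold lower number from compound 3 to compound 4 (0.25 log units; within the scatter).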

Compound 4, concentration for 50% growth inhibition: 6490 nM
Estimate against measurement, compound 4: 1.8-fold (0.27 log units) above; the measured number falls inside the stated range.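

In this assay, replacing methoxy with hydroxy on the core of compound 3 gave a 3.3-fold lower number from compound 3 to compound 4 (0.51 log units; beyond the scatter) and so produced a modest but readable gain in growth inhibition. This shows that the change cannot simply be carried from one core to another in this series at a fixed size, as the step on the core of compound 2 could not be told from scatter while the step on the core of compound 3 could. It does not show why the cores behave differently, and two cores give no rule for predicting the step on a third, but the gap between the two steps is itself clear: the same change on two cores in this assay, a 1.6-fold higher number (0.20 log units; within the scatter) from compound 2 to compound 1 and a 3.3-fold lower number (0.51 log units; beyond the scatter) from compound 3 to compound 4, 5.1-fold (0.71 log units) apart, beyond the scatter of two such steps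

The compounds shown carry only methoxy or hydroxy groups on the aromatic ring, so what an amine or a longer chain such as ethoxy would do in place of the hydroxy stays open. From the compounds shown here alone, whether a further core would follow the pair of compound 2 and compound 1 or the pair of compound 3 and compound 4 also remains open.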